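This account rests on a few compounds, and the source may have more. Where it says the series, first, only, none or still open, it means among the compounds named here.

Measured so far in an in vitro assay on AV12 cells for binding affinity to Neuropeptide Y receptor type 1 (Homo sapiens); a lower number here means a stronger inhibitor, a higher number a weaker inhibitor:
compound 1, `CN1CCC(CCCn2c(COc3ccccc3)nc3c(OCCCN4CCCCC4)cccc32)CC1`, gives 1.62 nM;
compound 2, `CC(C)CCN1CCC(CCCn2c(COc3ccccc3)nc3c(OCCCN4CCCCC4)cccc32)CC1`, gives 0.29 nM;
compound 3, `O=C(CCCN1CCC(CCCn2c(COc3ccccc3)nc3c(OCCCN4CCCCC4)cccc32)CC1)c1ccccc1`, gives 0.132 nM.

Compound 3 gives the lowest number of the three. Compound 2 stands nearest, separated by a 2.2-fold lower number from compound 2 to compound 3 (0.34 log units; beyond the scatter), and compound 1 furthest, separated by a 12-fold lower number from compound 1 to compound 3 (1.09 log units; beyond the scatter).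

Compound 4, `C(=C\c1ccccc1)\CN1CCC(CCCn2c(COc3ccccc3)nc3c(OCCCN4CCCCC4)cccc32)CC1`, has not yet been measured. It differs from compound 3 in one place: 2-phenylethenyl in place of 2-benzoylethyl on a saturated chain carbon bound to an amine nitrogen in a ring.

The measured steps that bear on this change all concern the same carbon. a 12-fold lower number from compound 1 to compound 3 (1.09 log units; beyond the scatter) shows what the 2-benzoylethyl group gives over hydrogen there; a 5.6-fold lower number from compound 1 to compound 2 (0.75 log units; beyond the scatter) shows the smaller gain from isobutyl at the same place; a 2.2-fold lower number from compound 2 to compound 3 (0.34 log units; beyond the scatter) separates the two substituted compounds. Compound 4 keeps an aromatic ring on the chain but carries no hydrogen-bond acceptor, and the change removes two heavy atoms. Within the data shown here, no measured step tests the carbonyl on its own, so the direction rests on the gap between the aromatic and the aliphatic substituent. Compound 4 is expected to show a modest upward step in this assay, a 1.9-fold higher number from compound 3 to compound 4 (0.28 log units; within the scatter). Compound 4 is estimated at 0.25 nM, with a range from 0.08 nM to 0.8 nM.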

Compound 4, inhibition constant: 0.183 nM
Compound 4: the middle estimate sits 1.4-fold (0.14 log units) above what was measured, and the stated range covers the measured number.
By their numbers in this assay, from the lowest: compounds 3, 4 and 2 (each within the scatter of the next, the first and the last beyond it); then compound 1.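

In this assay, 2-phenylethenyl stands in for 2-benzoylethyl on this saturated chain carbon with no step outside the scatter, a 1.4-fold higher number from compound 3 to compound 4 (0.14 log units; within the scatter), so the hydrogen-bond acceptor of the leaving group is not needed to hold a number of this size. The step to the aliphatic substituent also stays within the scatter, a 1.6-fold lower number from compound 2 to compound 4 (0.20 log units; within the scatter), so compound 4 does not separate from either substituted neighbour, and the small gap printed between the aromatic and aliphatic cases does not hold as a general aromatic-over-aliphatic pattern. The gain over hydrogen at this place does recur with a third substituent, an 8.9-fold lower number from compound 1 to compound 4 (0.95 log units; beyond the scatter), so all three substituted compounds sit beyond the scatter of compound 1 on the printed steps.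

Nothing shown gives a reason for these steps. Still open, as far as these compounds go, is how this place responds to a hydroxyl in place of the carbonyl, a saturated 3-phenylpropyl chain, a longer chain, or a terminal amine or carboxylic acid, any of which would test the carbonyl, the double bond and charge separately.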